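From 3-methoxyphenyl to cyclohexyl in a weakly active series

A few compounds are considered here, and "the series" means these few. Any claim that something is new, unique, unknown or untested is made for them only; others in the source may bear on it.

In a functional assay on MCF7 cells (Homo sapiens) for antiproliferative activity, read by MTT assay, with a stated time of 72 h (on this read-out lower numbers stand for stronger inhibition and higher numbers for weaker inhibition), compound 1 `COc1ncc(-c2ccc3c(c2)N(c2ccc(C)cc2)C(=O)CO3)cc1NS(=O)(=O)c1ccc(F)cc1` gives 15400 nM as a measured number. Compound 2 `COc1cccc(N2C(=O)COc3ccc(-c4cnc(Cl)c(NS(=O)(=O)c5ccc(F)cc5)c4)cc32)c1` gives > 40000 nM in this assay as a limit of the assay, not a number. Its standing is therefore the limit of > 40000 nM in this assay, at which 1 of the 2 values shown sits, and no exact strength can be read from it.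

Compound 3 `O=C1COc2ccc(-c3cnc(Cl)c(NS(=O)(=O)c4ccc(F)cc4)c3)cc2N1C1CCCCC1` carries cyclohexyl in place of 3-methoxyphenyl on an amide-type nitrogen in a ring. Going by the values given here, no measured pair shows this swap on its own, since compounds 1 and 2 differ in more than one place. Only a small step toward stronger inhibition is expected in this assay and it may stay within the scatter. Among the compounds with values here, with compound 1 at 15400 nM as the only measured number, nothing at hand points to strong inhibition for compound 3. The expected change runs an at least 1.3-fold lower number from compound 2 to compound 3 (0.12 log units; that floor lies within the scatter) and could well go unseen behind a limit of the assay. Compound 3 is estimated at 30000 nM with an expected range of 12000 nM to 70000 nM as the likely span.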

Compound 3, half-maximal inhibitory concentration: > 40000 nM
Compound 3: only a limit was reported; the forecaster's own chance of this, stated with the estimate: 45%; at least 1.3-fold (0.12 log units) between middle value and limit.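

Compound 2 and compound 3 each give only a limit of the assay, not a number, so no step can be read from one to the other: the limit of > 40000 nM in this assay, at which 2 of the 3 values shown sit.

On these data alone, whether swapping 3-methoxyphenyl for cyclohexyl on the amide-type nitrogen in a ring changes inhibition at all remains open.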